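Compound 4: nitro in place of methoxy, expected cytotoxicity

The compounds below may be only part of what the source reports. "The series", "measured", "known", "first", "only" and "open" are said of these compounds alone.

Compound 1 `COc1ccccc1C(C1=C(O)C(=O)c2ccccc2C1=O)c1c[nH]c2ccccc12` in a functional assay on ECa-109 cells (Homo sapiens) for cytotoxicity, read by MTT assay, with a stated time of 48 h (a lower number here means a stronger inhibitor, a higher number a weaker inhibitor), gives > 200000 nM, a limit of this assay.
Compound 2 `O=C1C(O)=C(C(c2ccc([N+](=O)[O-])cc2)c2c[nH]c3ccccc23)C(=O)c2ccccc21` gives 60900 nM.
Compound 3 `COc1cccc(C(C2=C(O)C(=O)c3ccccc3C2=O)c2c[nH]c3ccccc23)c1` gives 40000 nM.

Compound 3 holds the lower of the two numbers shown, yet compound 2 sits within the scatter of it, so the two cannot be ordered. Among the compounds with values here, the reading for compound 1 is the one value at the limit of > 200000 nM in this assay, at which 1 of the 3 values shown sits. Compound 4 `O=C1C(O)=C(C(c2cccc([N+](=O)[O-])c2)c2c[nH]c3ccccc23)C(=O)c2ccccc21` differs from compound 3 by nitro in place of methoxy on an aromatic carbon. The step that bears on this exchange is a 1.5-fold lower number from compound 2 to compound 3 (0.18 log units; within the scatter), which also swaps nitro against methoxy and stays within the scatter. The steps of an at least 3.2-fold lower number from compound 1 to compound 2 (0.51 log units; beyond the scatter) and an at least 5.0-fold lower number from compound 1 to compound 3 (0.69 log units; beyond the scatter) start from a limit and change the substituent's placement, so they give no guide. In this assay no movement beyond the scatter is therefore expected. The expected step is a 1.3-fold higher number from compound 3 to compound 4 (0.10 log units; within the scatter). Compound 4 is estimated at 50000 nM, with a range of 15000 nM to 150000 nM.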

Compound 4, half-maximal inhibitory concentration: 36200 nM
Compound 4: the middle estimate sits 1.4-fold (0.14 log units) above what was measured; low and high end bracket the measured number.
By their numbers in this assay, from the lowest: compounds 4, 3 and 2 (each within the scatter of the next). At a limit, above all of these: compound 1.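

In this assay, nitro and methoxy on this aromatic carbon, meta to a large group, cannot be told apart (a 1.1-fold lower number from compound 3 to compound 4 (0.04 log units; within the scatter)). Placement of the nitro is equally unresolved, so 3-nitrophenyl and 4-nitrophenyl cannot be ordered (a 1.7-fold lower number from compound 2 to compound 4 (0.23 log units; within the scatter)). Within the data shown here, the only step beyond the scatter starts from compound 1, whose reading is a limit (an at least 5.5-fold lower number from compound 1 to compound 4 (0.74 log units; beyond the scatter)), and that reading stands alone: the limit of > 200000 nM in this assay, at which 1 of the 4 values shown sits.

Still open, going by these compounds, is whether an amine or a carboxylic acid on this carbon would move the number beyond the scatter.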